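From Butyl to Phenoxy at the Assay Limit

A few compounds are considered here, and "the series" means these few. Any claim that something is new, unique, unknown or untested is made for them only; others in the source may bear on it.

Three amides on a shared core have been read in an ADME assay on microsomes from liver (Mus musculus) for metabolic stability, read by LC-MS, with NADPH named in the record, with a stated time of 60 min, tested at 1 uM, in the absence of a further agent; a higher number here means that more of the compound is left, a lower number that less of the compound is left. Compound 1 `COc1ccc(-c2c(C)nc3c(N4CC[C@@H](NC(C)=O)C4)cc(C)nn23)cc1OC` gives > 95%, which is a limit and not a number. Compound 2 `COc1ccc(-c2c(C)nc3c(N4CC[C@@H](NC(=O)C(F)(F)F)C4)cc(C)nn23)cc1OC` gives > 95%, also a limit. Compound 3 `CCCCCC(=O)N[C@@H]1CCN(c2cc(C)nn3c(-c4ccc(OC)c(OC)c4)c(C)nc23)C1` gives > 95%, again a limit. So compound 3 has no exact value, and the evidence amounts to the limit of > 95% in this assay, at which 3 of the 3 values shown sit.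

Compound 4 `COc1ccc(-c2c(C)nc3c(N4CC[C@@H](NC(=O)COc5ccccc5)C4)cc(C)nn23)cc1OC` differs from compound 3 by phenoxy in place of butyl on a saturated chain carbon bound to a carbonyl carbon, with phenoxy in place of butyl on a saturated chain carbon bound to a carbonyl carbon. For the measured compounds named here, the steps that bear on this change are those that alter the group on the same carbonyl carbon, namely a step that the two limits leave unreadable from compound 1 to compound 3 and a step that the two limits leave unreadable from compound 2 to compound 3. Neither has a readable size, so the series offers no measured effect of this group to carry over. No step beyond the usual scatter is expected, and any shift is expected to be downward, with an estimated step of a number at least 5 percentage points lower from compound 3 to compound 4 (that floor lies within the scatter). For compound 4 the expected value is 90%, with an estimated range of 70% to 100%.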

Compound 4, percent of the compound remaining: > 95%
Compound 4: a limit, no number (the forecaster's own chance of this, stated with the estimate: 50%); at least 5 percentage points between middle value and limit.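

Compound 4, like compound 1, compound 2 and compound 3, gives only a limit in this assay, so none of the steps from those three compounds to compound 4 can be read. The compounds shown leave open how far any of these groups on the carbonyl carbon shifts the percent remaining, given where they all sit: the limit of > 95% in this assay, at which 4 of the 4 values shown sit.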